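The source may hold more compounds than are shown below. What is called first, only, known or untested is meant among the compounds shown, and "the series" means these compounds.

Three compounds share one core and differ only in the aryl group attached to an aromatic nitrogen of the five-membered aromatic ring with three nitrogens. Compound 1 `Cc1ccccc1-n1cc(COc2cccc(NC(=O)Nc3ccc(Cl)c(C(F)(F)F)c3)c2)nn1` carries a 2-methylphenyl there, and in a functional assay on HepG2 cells (Homo sapiens) for inhibition, read by MTT assay, with a stated time of 72 h (on this read-out lower numbers stand for stronger inhibition and higher numbers for weaker inhibition), compound 1 gives 3440 nM. Compound 2 `COc1ccc(-n2cc(COc3cccc(NC(=O)Nc4ccc(Cl)c(C(F)(F)F)c4)c3)nn2)cc1` carries a 4-methoxyphenyl, and in this assay compound 2 gives 4680 nM. Compound 3 `Cc1cccc(-n2cc(COc3cccc(NC(=O)Nc4ccc(Cl)c(C(F)(F)F)c4)c3)nn2)c1` carries a 3-methylphenyl, and in this assay compound 3 gives 7270 nM, the highest of the three numbers; the gap to compound 2 is within the scatter, the gap to compound 1 is not.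

Compound 4 `N#Cc1ccccc1-n1cc(COc2cccc(NC(=O)Nc3ccc(Cl)c(C(F)(F)F)c3)c2)nn1` is reached from compound 3 by a single change: 2-cyanophenyl in place of 3-methylphenyl on an aromatic nitrogen. For the measured compounds named here, two measured steps bear on this exchange of the aryl group. The step of a 2.1-fold higher number from compound 1 to compound 3 (0.32 log units; beyond the scatter) is the only one beyond the scatter, while a 1.6-fold higher number from compound 2 to compound 3 (0.19 log units; within the scatter) stays within it. Going by the values given here, no measured compound carries a nitrile, so the effect of the 2-cyanophenyl itself is unknown. Among the compounds with values here, compound 1, the one measured compound with a 2-substituted phenyl, gave the lowest number, and on that basis a modest lower number is expected for compound 4, a step of a 1.8-fold lower number from compound 3 to compound 4 (0.26 log units; within the scatter). In this assay compound 4 is therefore estimated at 4000 nM, with a range from 1500 nM to 10000 nM.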

Compound 4, half-maximal inhibitory concentration: 1970 nM
Beside the measured number, compound 4's estimate is 2.0-fold (0.31 log units) above it; measured number inside the range.
By their numbers in this assay, from the lowest: compounds 4, 1, 2 and 3 (each within the scatter of the next, the first and the last beyond it).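

In this assay, for the compounds shown here, the 2-cyanophenyl gives a 3.7-fold lower number from compound 3 to compound 4 (0.57 log units; beyond the scatter) and also a 2.4-fold lower number from compound 2 to compound 4 (0.38 log units; beyond the scatter) from the 4-methoxyphenyl, a group that compound 1 could not be told apart from, so this is the first aryl group here to stand clear of both of the other two. Exchanging methyl for cyano on the same ring carbon gives only a 1.7-fold lower number from compound 1 to compound 4 (0.24 log units; within the scatter) and so no real difference, which means that compound 1 and compound 4, the two compounds with a group at the 2-position of the phenyl, both stand clear of compound 3, while compound 2 goes against any simple reading by position because it differs from compound 1 only within the scatter. Nothing given here explains why the numbers fall this way.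

From the compounds shown here alone, whether a nitrile would keep this number at another place on the phenyl ring remains open. So does the question of what an amine or a carboxylic acid would do on the ring carbon that holds the nitrile in compound 4.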